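Replacing the Diethylamino Group of Compound 3

A few compounds are considered here, and "the series" means these few. Any claim that something is new, unique, unknown or untested is made for them only; others in the source may bear on it.

In a functional assay on MIA PaCa-2 cells (Homo sapiens) for inhibition, read by MTT assay, with a stated time of 48 h, tested at 10 uM (on this read-out higher numbers stand for more inhibition of growth at the one concentration tested and lower numbers for less inhibition of growth), three compounds on a shared core have been measured so far. Compound 1 (`COc1ccc(COc2cc(O)c3c(=O)cc(C)oc3c2[C@H]2CCN(C)C[C@H]2O)cc1`) gives 15% there, and compound 2 (`Cc1cc(=O)c2c(O)cc(OCc3ccccc3Br)c([C@H]3CCN(C)C[C@H]3O)c2o1`) gives 30% there. Compound 3 (`CCN(CC)Cc1c(O)c([C@H]2CCN(C)C[C@H]2O)c2oc(C)cc(=O)c2c1O`) gives 27% there, which cannot be told apart from compound 2 and stands beyond the scatter above compound 1.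

Compound 4 (`Cc1cc(=O)c2c(O)c(CN3CCCC3C(=O)O)c(O)c([C@H]3CCN(C)C[C@H]3O)c2o1`) carries 2-carboxypyrrolidin-1-yl in place of diethylamino on a saturated chain carbon bound to an aromatic carbon. Going by the values given here, no measured step covers this exchange. Among the compounds with values here, the one step available (a number 15 percentage points higher from compound 1 to compound 2 (beyond the scatter)) is modest and lies elsewhere, on a saturated chain carbon bound to an oxygen on an aromatic ring, so it offers only a loose guide to size and none to direction. A change no larger than that modest step is therefore expected, most likely none beyond the scatter, with a slight downward lean held only tentatively. The estimated step (a number 5 percentage points lower from compound 3 to compound 4 (within the scatter)) is accordingly small. For compound 4 the estimate is 22% with an expected range from 8% to 36% once it is measured.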

Compound 4, percent growth inhibition at one concentration: 10%
Beside the measured number, compound 4's estimate is 12 percentage points above it; low and high end bracket the measured number.
By their numbers in this assay, from the lowest: compounds 4 and 1 (each within the scatter of the next); then compounds 3 and 2 (each within the scatter of the next).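

At the saturated chain carbon bound to an aromatic carbon, the position proves sensitive to the group carried there: in this assay, 2-carboxypyrrolidin-1-yl in place of diethylamino gives a number 17 percentage points lower from compound 3 to compound 4 (beyond the scatter), a modest step. This single exchange brings in a five-membered non-aromatic ring and a carboxy group together, so the step cannot be assigned to either one alone. Nothing available explains the drop in growth inhibition.

From the compounds shown here alone, it remains open whether the step follows the ring or the carboxy group, a question that pyrrolidin-1-yl without the carboxy group, or a methyl ester in place of the carboxylic acid, would address. Also unsettled is how an amine with longer chains, such as dipropylamino, would read at this place.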